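From dibutylamino to cyclohexylamino on a shared core

The source may report more compounds than this note shows. Statements on the series, on what has been measured and on what is new or still open speak of the compounds shown alone.

Compound 2 (`CCCCN(CCCC)c1nc(SCC)nc2c1ncn2[C@@H]1O[C@H](CO)[C@@H](O)[C@H]1O`) offers no number to start from: in a functional assay on a cell-free system (Platelet, plasma, Homo sapiens) for inhibition, with stated times of 1 min and 3 min (on this read-out lower numbers stand for stronger inhibition and higher numbers for weaker inhibition), compound 2 gives "not determined" (no result reported) as its result. Going by the values given here, compound 1 (`CCCCSc1nc(NC2CCCCC2)c2ncn([C@@H]3O[C@H](CO)[C@@H](O)[C@H]3O)c2n1`), which also carries cyclohexylamino, gives 83000 nM as the only measured value. Compound 3 (`CCSc1nc(NC2CCCCC2)c2ncn([C@@H]3O[C@H](CO)[C@@H](O)[C@H]3O)c2n1`) follows through cyclohexylamino in place of dibutylamino on an aromatic carbon with cyclohexylamino in place of dibutylamino on an aromatic carbon. Among the compounds with values here, no measured step shows what this swap does, so in this assay compound 1 at 83000 nM stays the only guide, and compound 3 is not expected to differ from it by more than the usual scatter, in either direction. For compound 3 the estimated value is 80000 nM within an expected range of 30000 nM to 250000 nM for now.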

Compound 3, half-maximal inhibitory concentration: 104000 nM
For compound 3 the middle estimate is 1.3-fold (0.11 log units) below the measured one, and the stated range covers the measured number.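

Replacing ethyl with hydrogen on the saturated chain carbon two bonds along from the sulfur, which leaves the ethylsulfanyl group, gives a 1.3-fold higher number from compound 1 to compound 3 (0.10 log units; within the scatter) in this assay, so with cyclohexylamino kept, this shift along the sulfur chain leaves the two compounds indistinguishable. The swap from dibutylamino to cyclohexylamino still cannot be read, since compound 2 has no number. Nothing available explains the result. Going by these compounds, how a carboxylic acid or an amine on the sulfur chain would read out remains open, as does whether any other group on the aromatic carbon would move the number beyond the scatter.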